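Chain Lengthening on the Amide Carbon of a Fluorinated Benzylamide

The source may report more compounds than this note shows. Statements on the series, on what has been measured and on what is new or still open speak of the compounds shown alone.

Measured so far:
Compound 1, `COc1ccc(F)c(CNC(C)=O)c1`, gives 100%.
Compound 2, `CCC(=O)NCc1cc(OC)ccc1F`, gives 69%.

Both numbers come from an assay on isolated protein for agonist activity at melatonin receptor type 1C (Xenopus laevis), read by spectrophotometry; a higher number here means a larger maximal response, a lower number a smaller maximal response. Within the data shown here, compound 2 stands at the lower of the two values, with compound 1 the only other measured compound and its value beyond the scatter above that of compound 2. Among the measured compounds shown here, the one measured step, a number 31 percentage points lower from compound 1 to compound 2 (beyond the scatter), came with a change of the same kind as the one now in question: the carbon chain on the carbonyl side of the amide grew by one carbon.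

Compound 3, `CCCC(=O)NCc1cc(OC)ccc1F`, is not yet measured in this assay. It differs from compound 2 by methyl in place of hydrogen on a saturated chain carbon, two bonds along the chain from a carbonyl carbon. The chain grows again by a single carbon, only one bond further out than in the step from compound 1 to compound 2. For the measured compounds named here, that step is the sole guide here, and it was large and downward. Going by the values given here, on that basis a further drop in this assay is expected for compound 3, though with only one step to rest on the size is uncertain, and the expected step is a number 19 percentage points lower from compound 2 to compound 3 (beyond the scatter). The estimate for compound 3 is therefore 50%, expected to lie between 30% and 75%.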

Compound 3, largest response reached (reported as efficacy), in percent of the reference or control that the assay uses: 43%
The estimate for compound 3 lay 7 percentage points above the measured number; the range from low to high includes it.
By their numbers in this assay, from the lowest: compound 3; then compound 2; then compound 1.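

In this assay, extending the chain once more lowered the maximal response again, with a number 26 percentage points lower from compound 2 to compound 3 (beyond the scatter), so the loss is not confined to the saturated chain carbon bound to a carbonyl carbon and also appears when methyl replaces hydrogen two bonds along the chain from a carbonyl carbon. Taken as a single change, ethyl in place of hydrogen on the saturated chain carbon bound to a carbonyl carbon gives a number 57 percentage points lower from compound 1 to compound 3 (beyond the scatter), and across these three compounds the response falls with each added carbon, with none of them going against that order. Nothing available here gives a reason for this decline.

The compounds shown leave open whether a butyl or still longer chain on the carbonyl carbon would take the response lower or whether the decline would level off. They also leave open whether the carbon count alone follows the response, a question that a branched isopropyl group, a cyclopropyl ring or a methoxymethyl chain in the same place could address.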